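The source may report more compounds than this note shows. Statements on the series, on what has been measured and on what is new or still open speak of the compounds shown alone.

Working notes on the series. All compounds share one core and differ in the ether-linked chain and the amine at its end. In an assay on isolated protein for inhibition of Amine oxidase [flavin-containing] B (Homo sapiens), read by fluorescence, with a stated time of 30 min (a lower number here means a stronger inhibitor, a higher number a weaker inhibitor), compound 1 `CC(=O)c1ccc(OCCCN2CCC(Cc3ccccc3)CC2)cc1O` gives 18700 nM. Compound 2 `CC(=O)c1ccc(OCCCCCCCCCCCCN2CCC(Cc3ccccc3)CC2)cc1O` gives 25800 nM. Compound 3 `CCN(CC)CCCCCCOc1ccc(C(C)=O)c(O)c1` gives 22100 nM, the second highest of the three numbers, within the scatter of both compound 2 and compound 1. Compound 4 `CCN(CC)CCCCOc1ccc(C(C)=O)c(O)c1` has not yet been measured in this assay; it differs from compound 3 by diethylamino in place of 2-(diethylamino)ethyl on a saturated chain carbon, four bonds along the chain from an oxygen on an aromatic ring. Compound 1 and compound 2 carry the shortest and longest chains here, yet their numbers lie close together, so for compound 4 no step beyond the scatter is expected in this assay. Compound 4 is expected at 22000 nM, with a range from 10000 nM to 48000 nM, an expected step of a 1.0-fold lower number from compound 3 to compound 4 (0.00 log units; within the scatter).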

Compound 4, half-maximal inhibitory concentration: 22200 nM
Estimate against measurement, compound 4: 1.0-fold (0.00 log units) below; the measured number falls inside the stated range.
By their numbers in this assay, from the lowest: compounds 1, 3, 4 and 2 (each within the scatter of the next).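

In this assay, among the compounds shown here, the swap of 2-(diethylamino)ethyl for diethylamino on a saturated chain carbon gives a 1.0-fold higher number from compound 3 to compound 4 (0.00 log units; within the scatter) and is the first step read between two compounds that differ in one place. At this position, a chain end smaller by two carbons leaves compound 3 and compound 4 indistinguishable in this measurement. No measurement at hand bears on why the pair reads alike. In this assay, from the compounds shown here alone, it remains open whether a morpholine or a carboxylic acid at the chain end would give a step beyond the scatter.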